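The source may hold more compounds than are shown below. What is called first, only, known or untested is meant among the compounds shown, and "the series" means these compounds.

Three of the four compounds in this small set have been tested in an ADME assay on HEK293 cells (Homo sapiens) for inhibition, read by MTT assay, with stated times of 18 h and 4 h (on this read-out higher numbers stand for weaker inhibition and lower numbers for stronger inhibition), and the fourth waits to be estimated. Compound 1 `CCCCCCCCCCOP(=O)(O)OCCSC(=S)N1CCCCCC1` gives 70000 nM in this assay. Compound 2 `CCCCCCCCCCOP(=O)(O)OCCSC(=S)N1CCN(C)CC1` carries a different ring on the thiocarbonyl carbon. For compound 2 this assay reports only a limit, > 100000 nM, and not a number, which is the limit of > 100000 nM in this assay, at which 1 of the 3 values shown sits. Compound 3 `CCCCCCCCOP(=O)(O)OCCSC(=S)N1CCN(C)CC1` keeps the ring of compound 2 but has a shorter chain, and in this assay compound 3 gives 86000 nM.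

Two single changes tie the measured compounds together. The ring swap, (azepan-1-yl in place of 4-methylpiperazin-1-yl on a thiocarbonyl carbon), gives a step of an at least 1.4-fold lower number from compound 2 to compound 1 (0.15 log units; that floor lies within the scatter). The shortening of the chain, (hydrogen in place of ethyl on a saturated chain carbon, eight bonds along the chain from an oxygen on an unsaturated carbon), gives an at least 1.1-fold lower number from compound 2 to compound 3 (0.06 log units; that floor lies within the scatter); this is also how the core of compound 3 differs from the core of compound 2.

Compound 4 `CCCCCCCCOP(=O)(O)OCCSC(=S)N1CCCCCC1` has not been measured. It stands to compound 3 exactly as compound 1 stands to compound 2, through (azepan-1-yl in place of 4-methylpiperazin-1-yl on a thiocarbonyl carbon), and the place of the change reads the same in both pairs, so it is the same change. For compound 4 the expected step is a 1.4-fold lower number from compound 3 to compound 4 (0.16 log units; within the scatter), set beside the measured at least 1.4-fold lower number from compound 2 to compound 1 (0.15 log units; that floor lies within the scatter), which rests on compound 1 and compound 2 alone. Compound 4 is therefore estimated at 60000 nM in this assay. The expected range for compound 4 runs from 30000 nM to 100000 nM.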

Compound 4, half-maximal inhibitory concentration: > 100000 nM
Compound 4 gave a limit, no number (the forecaster's own chance of this, stated with the estimate: 20%); middle value at least 1.6-fold (0.22 log units) away from the limit.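

With azepan-1-yl in place of 4-methylpiperazin-1-yl on a thiocarbonyl carbon, the new step of an at least 1.1-fold higher number from compound 3 to compound 4 (0.06 log units; that floor lies within the scatter) ends on a limit and not on a number, and it can only be set beside the step for the same change on the other core: the same change on two cores in this assay, an at least 1.4-fold lower number (0.15 log units; that floor lies within the scatter) from compound 2 to compound 1 and an at least 1.1-fold higher number (0.06 log units; that floor lies within the scatter) from compound 3 to compound 4; the limit leaves it open whether they differ

The change of chain gives an at least 1.4-fold higher number from compound 1 to compound 4 (0.15 log units; that floor lies within the scatter), which ends on the same limit and meets the same difficulty when set beside its earlier counterpart: the same change on two cores in this assay, an at least 1.1-fold lower number (0.06 log units; that floor lies within the scatter) from compound 2 to compound 3 and an at least 1.4-fold higher number (0.15 log units; that floor lies within the scatter) from compound 1 to compound 4; the limit leaves it open whether they differ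

Neither change is therefore shown to carry over from one core to the other, and neither is shown to fail to carry over, since limits make up much of this small set: the limit of > 100000 nM in this assay, at which 2 of the 4 values shown sit.

The compounds shown leave open what number compound 4 would give if it could be read on a scale without that limit, and so how large the ring change really is on the shorter chain. They also leave open whether the pattern would look the same with a piperidin-1-yl or morpholin-4-yl group on the thiocarbonyl carbon, or with a longer chain such as dodecyl on the phosphate.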